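The source may report more compounds than this note shows. Statements on the series, on what has been measured and on what is new or still open speak of the compounds shown alone.

Going by the values given here, compound 1 `C[C@@H](NC(=O)Nc1ccccc1C(F)(F)F)c1ccccc1` is one of three compounds measured in an ADME assay on the whole organism with Oryza sativa as the target, tested at 0.1 uM (a higher number here means a weaker effect of the compound at the concentration tested, a lower number a stronger effect), in which compound 1 gives 99%. Its mirror image, compound 2 `C[C@H](NC(=O)Nc1ccccc1C(F)(F)F)c1ccccc1`, gives 97% in this assay, a step of a number 2 percentage points lower from compound 1 to compound 2 (within the scatter), which is within the scatter and is linked to the fact that compounds 1 and 2 differ only in the configuration as drawn. Compound 3 `COc1cccc(NC(=O)N[C@@H](C)c2ccccc2)c1`, whose urea carries a methoxy-bearing ring in place of the trifluoromethyl-bearing one, gives 101%. Compound 1 therefore stands second highest of the three numbers, with compound 2 nearest and compound 3 furthest, all three within the scatter of one another.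

The step to compound 4 `C[C@@H](NC(=O)Nc1ccccc1I)c1ccccc1` is iodo in place of trifluoromethyl on an aromatic carbon. Among the compounds with values here, none of the measured steps changes this group: the only step measured, from compound 1 to compound 2, concerns configuration alone, so no step of like kind is known. Within the data shown here, since every compound measured so far sits at essentially full activity, compound 4 is expected to show no step beyond the scatter, a number 1 percentage points lower from compound 1 to compound 4 (within the scatter), and its estimated value in this assay is 98%, within 90% to 104%.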

Compound 4, a percentage reported as activity, at one concentration (the size of the read-out at that concentration, not a potency): 100%
The estimate for compound 4 lay 2 percentage points below the measured number; measured number inside the range.
By their numbers in this assay, from the lowest: compounds 2, 1, 4 and 3 (each within the scatter of the next).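

Iodo in place of trifluoromethyl on an aromatic carbon, ortho to a large group, gives in this assay a number 1 percentage points higher from compound 1 to compound 4 (within the scatter) and so exchanges four heavy atoms for one without a step beyond the scatter. This pair therefore shows a change of the group itself at this place, which the earlier step, confined to configuration, could not show, though it gives no order between the two groups. Nothing known about these compounds bears on this step.

It remains open whether any group at this place moves the number beyond the scatter, since an amine, a carboxylic acid or a nitrile on this aromatic carbon is not among the compounds shown. On these data alone, it is also open whether iodo gives the same picture with the stereocentre drawn S.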